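A few compounds are considered here, and "the series" means these few. Any claim that something is new, unique, unknown or untested is made for them only; others in the source may bear on it.

Values in a functional assay on MCF7 cells (Homo sapiens) for inhibition, read by sulforhodamine B assay, with a stated time of 48 h; a lower number here means a stronger inhibitor, a higher number a weaker inhibitor:
- compound 1 `COc1ccc(C(OCc2ccccc2)c2cccc3ccccc23)c(OC)c1OC` gives 14100 nM
- compound 2 `COc1ccc(C(c2ccc(OCCO)cc2)c2cccc3ccccc23)c(OC)c1OC` gives > 20000 nM, a limit and not a number
- compound 3 `COc1ccc(/C(=C\c2ccc(F)cc2)c2cccc3ccccc23)c(OC)c1OC` gives 17700 nM

Compound 2 has no number, only (the limit of > 20000 nM in this assay, at which 1 of the 3 values shown sits). Compound 4 `COc1ccc(C(c2ccc(O)cc2)c2cccc3ccccc23)c(OC)c1OC` carries hydrogen in place of 2-hydroxyethyl on an oxygen on an aromatic ring. For the measured compounds named here, only one measured step bears on this part of the series, an at least 1.4-fold higher number from compound 1 to compound 2 (0.15 log units; that floor lies within the scatter), and it changes a different group, so it sets no size for this change. Going by the values given here, compound 1 at 14100 nM and compound 3 at 17700 nM are the only numbers nearby, so a modest move in this assay is expected, towards a lower number if there is any move at all. The expected step is an at least 1.6-fold lower number from compound 2 to compound 4 (0.22 log units; that floor lies within the scatter). For compound 4 the estimated value is 12000 nM, with an expected range of 4000 nM to 30000 nM.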

Compound 4, half-maximal inhibitory concentration: 17500 nM
Compound 4: the middle estimate sits 1.5-fold (0.16 log units) below what was measured; measured number inside the range.
By their numbers in this assay, from the lowest: compounds 1, 4 and 3 (each within the scatter of the next). At a limit, above all of these: compound 2.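

Cutting 2-hydroxyethoxy back to hydroxy gives an at least 1.1-fold lower number from compound 2 to compound 4 (0.05 log units; that floor lies within the scatter) in this assay, so only a floor is available for this change. Compound 2 carries a limit and not a number: the limit of > 20000 nM in this assay, at which 1 of the 4 values shown sits.
4-Hydroxyphenyl in place of benzyloxy on the saturated chain carbon gives a 1.2-fold higher number from compound 1 to compound 4 (0.09 log units; within the scatter), so these two groups are not told apart in this assay.

Still open, going by these compounds, is whether a longer chain ending in an amine or a carboxylic acid on that oxygen would shift the number beyond the scatter. On these data alone, the true size of the step from 2-hydroxyethyl to hydrogen also remains unknown.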